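Moving the chlorine on the benzylthio arm

The source may report more compounds than this note shows. Statements on the series, on what has been measured and on what is new or still open speak of the compounds shown alone.

Compound 1 `CC1=C(C(=O)Nc2ccc(F)cc2)C(c2ccc([N+](=O)[O-])cc2)N=C(SCc2cccc(Cl)c2)N1`: 15.9%
Compound 2 `CC1=C(C(=O)Nc2ccc(F)cc2)C(c2ccc([N+](=O)[O-])cc2)N=C(SCc2ccc(Cl)cc2)N1`: 33.3%
Compound 3 `CC1=C(C(=O)Nc2ccc(Br)cc2)C(c2ccc(Cl)cc2Cl)N=C(SCc2cccc(Cl)c2)N1`: 15.9%

In a functional assay on the whole organism (artery, strain albino) with Rattus norvegicus as the target, with a stated time of 240 min, at a dose of 10 mg/kg by the oral route (on this read-out higher numbers stand for more inhibition at the one dose given (going by the name of the read-out) and lower numbers for less inhibition), compound 1 gives 15.9% and compound 2 gives 33.3%. The only structural difference between the two is 4-chlorophenyl in place of 3-chlorophenyl on a saturated chain carbon bound to a sulfur, and this change made a number 17.4 percentage points higher from compound 1 to compound 2 (beyond the scatter). Compound 3 carries a different core; the difference between the two cores is not broken down here. In this assay compound 3 gives 15.9%, within the scatter of compound 1. Compound 4 `CC1=C(C(=O)Nc2ccc(Br)cc2)C(c2ccc(Cl)cc2Cl)N=C(SCc2ccc(Cl)cc2)N1` has not yet been measured. It differs from compound 3 by 4-chlorophenyl in place of 3-chlorophenyl on a saturated chain carbon bound to a sulfur, the same change as from compound 1 to compound 2. Because the earlier step was a number 17.4 percentage points higher from compound 1 to compound 2 (beyond the scatter), a rise of similar size is expected for compound 4, a step of a number 13.1 percentage points higher from compound 3 to compound 4 (beyond the scatter). Going by the values given here, with only one example of this change to go on, the estimate for compound 4 is 29%, expected to lie between 12% and 46%.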

Compound 4, a percentage reported as inhibition, in the whole organism at one dose (the size of the read-out at that dose, not a potency): 32.3%
The estimate for compound 4 lay 3.3 percentage points below the measured number; the measured number falls inside the stated range.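

In this assay, exchanging 3-chlorobenzyl for 4-chlorobenzyl on the sulfur gave a number 16.4 percentage points higher from compound 3 to compound 4 (beyond the scatter). Set beside the earlier step, the change carried over from one core to the other with much the same size: the same change on two cores in this assay, a number 17.4 percentage points higher (beyond the scatter) from compound 1 to compound 2 and a number 16.4 percentage points higher (beyond the scatter) from compound 3 to compound 4, 1 percentage points apart, within the scatter of two such steps. This shows that in these two matched pairs the gain did not depend on which of the two cores carried the benzyl group, but two pairs cannot show that it would hold on other cores in the series, and they do not explain why the chlorine's place matters.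

The compounds shown leave open whether the chlorine itself is needed for this gain. They also leave open how the read-out would respond to a plain benzyl group, an amine or a longer chain on the sulfur.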